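Ethyl for fluorobenzyl on the aromatic nitrogen of the shared core

This account rests on a few compounds, and the source may have more. Where it says the series, first, only, none or still open, it means among the compounds named here.

Measured so far in an ADME assay on MDBK cells (Bos taurus) for cytotoxicity; on this read-out higher numbers stand for lower toxicity in this test and lower numbers for higher toxicity in this test:
compound 1 `Fc1ccc(Cn2ccc3nc(-c4ccccc4)nc-3c2)cc1` gives > 100000 nM
compound 2 `FC(F)(F)Oc1ccc(Cn2ccc3nc(-c4ccccc4)nc-3c2)cc1` gives 66000 nM

The value of compound 1 is a limit of this assay, not a number (the limit of > 100000 nM in this assay, at which 1 of the 2 values shown sits). From compound 1 to compound 2 the change is trifluoromethoxy in place of fluoro on an aromatic carbon, and the step is an at least 1.5-fold lower number from compound 1 to compound 2 (0.18 log units; that floor lies within the scatter).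

Compound 3 `CCn1ccc2nc(-c3ccccc3)nc-2c1` remains to be measured. It differs from compound 1 as follows: methyl in place of 4-fluorophenyl on a saturated chain carbon bound to an aromatic nitrogen. Going by the values given here, the one measured step alters only the substituent on the aromatic ring that leaves here, so no measured step bears directly on the exchange of that whole ring for methyl. Both measured values sit at low toxicity, and no step beyond the scatter has been seen in the series. Compound 3 is therefore expected to give about 100000 nM, between 40000 nM and 250000 nM, a change of a number no higher from compound 1 to compound 3 (the limit leaves the size open) that is expected to stay within the scatter, with a fair chance that only a limit is reported again.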

Compound 3, half-maximal cytotoxic concentration: > 100000 nM
Compound 3 was reported as a limit; the forecaster's own chance of this, stated with the estimate: 55%; the middle value sits exactly at the limit.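

In this assay compound 3 gives > 100000 nM as a limit and not a number. Going by these compounds alone, compound 1 also stands at a limit, and no step between compound 1 and compound 3 can be read: the limit of > 100000 nM in this assay, at which 2 of the 3 values shown sit. The compounds shown leave open whether methyl in place of 4-fluorophenyl changes the read-out at all, and by how much.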